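Moving the Thiophene Attachment Point

The source may hold more compounds than are shown below. What is called first, only, known or untested is meant among the compounds shown, and "the series" means these compounds.

Measured in a functional assay on G-361 cells (Homo sapiens) for inhibition, with a stated time of 72 h; a lower number here means a stronger inhibitor, a higher number a weaker inhibitor:
Compound 1 `NC1CCC(Nc2nc(NCc3ccc(-c4ccccc4)nc3)c3ncn(C4CCCC4)c3n2)CC1`: 895 nM
Compound 2 `NC1CCC(Nc2nc(NCc3ccc(-c4cccs4)nc3)c3ncn(C4CCCC4)c3n2)CC1`: 150 nM

Of these two measured compounds, compound 2 has the lower number, at 150 nM. For the measured compounds named here, the only measured step, a 6.0-fold lower number from compound 1 to compound 2 (0.78 log units; beyond the scatter), came with thiophen-2-yl in place of phenyl on an aromatic carbon. Compound 3 `NC1CCC(Nc2nc(NCc3ccc(-c4ccsc4)nc3)c3ncn(C4CCCC4)c3n2)CC1` has not yet been measured. It differs from compound 2 by thiophen-3-yl in place of thiophen-2-yl on an aromatic carbon, with thiophen-3-yl in place of thiophen-2-yl, next to the ring nitrogen. Going by the values given here, no measured step covers this exchange directly. The step above replaced one ring type with another, whereas here the five-membered aromatic ring with 1 hetero atom stays and only its point of attachment moves. A much smaller step is therefore expected in this assay, perhaps slightly upward and possibly within the scatter. The expected change is a 1.3-fold higher number from compound 2 to compound 3 (0.12 log units; within the scatter). For compound 3 the estimated value is 200 nM, with an expected range from 80 nM to 500 nM.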

Compound 3, half-maximal inhibitory concentration: 272 nM
Beside the measured number, compound 3's estimate is 1.4-fold (0.13 log units) below it; low and high end bracket the measured number.
By their numbers in this assay, from the lowest: compounds 2 and 3 (each within the scatter of the next); then compound 1.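

In this assay moving the attachment point of the thiophene gives a 1.8-fold higher number from compound 2 to compound 3 (0.26 log units; within the scatter) and so leaves thiophen-2-yl and thiophen-3-yl indistinguishable at this position next to the ring nitrogen. The lower number seen on leaving phenyl therefore does not depend on a single attachment point: thiophen-3-yl gives a 3.3-fold lower number from compound 1 to compound 3 (0.52 log units; beyond the scatter) and thiophen-2-yl gives a 6.0-fold lower number from compound 1 to compound 2 (0.78 log units; beyond the scatter) as well. Among the compounds shown, both thiophene isomers thus stand apart from the phenyl compound, while the position of the sulfur within the ring makes no difference that can be read beyond the scatter.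

Going by these compounds, it remains open whether a furan-2-yl, a thiazol-2-yl or a pyridin-3-yl ring in this place would behave like the thiophenes or like phenyl. Nothing available explains why the thiophenes differ from phenyl here.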